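Swapping Methoxyphenyl for Pyridyl on the Amide Arm

The source may report more compounds than this note shows. Statements on the series, on what has been measured and on what is new or still open speak of the compounds shown alone.

Compound 1 `Cc1ccc(CNC(=O)CC2c3ccccc3N=C(N3CCN(CCN(C)C)CC3)N2c2ccc(-c3ccccc3)cc2)cc1`: 3520 nM
Compound 2 `COc1ccc(CNC(=O)CC2c3ccccc3N=C(N3CCN(CCN(C)C)CC3)N2c2ccc(-c3ccccc3)cc2)cc1`: 3820 nM

In a functional assay on cells (Homo sapiens) for cytotoxicity, read by MTT assay, with a stated time of 48 h (a lower number here means a stronger inhibitor, a higher number a weaker inhibitor), compound 2 stands beside compound 1, the step of a 1.1-fold higher number from compound 1 to compound 2 (0.04 log units; within the scatter) lying within the scatter. Compound 3 `CN(C)CCN1CCN(C2=Nc3ccccc3C(CC(=O)NCc3ccccn3)N2c2ccc(-c3ccccc3)cc2)CC1` differs from compound 2 by pyridin-2-yl in place of 4-methoxyphenyl on a saturated chain carbon bound to an amide-type nitrogen. Within the data shown here, the only measured step at this place, a 1.1-fold higher number from compound 1 to compound 2 (0.04 log units; within the scatter), stayed within the scatter, so no step beyond the scatter is expected in this assay for compound 3, in either direction. The estimate for compound 3 is 3600 nM, with a range from 1500 nM to 8500 nM, which is expected to correspond to a step of a 1.1-fold lower number from compound 2 to compound 3 (0.03 log units; within the scatter).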

Compound 3, half-maximal inhibitory concentration: > 5000 nM
Compound 3: no number, only a limit; the forecaster's own chance of this, stated with the estimate: 5%; middle value at least 1.3-fold (0.14 log units) away from the limit.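

Compound 3 gives no number here, only a limit: the limit of > 5000 nM in this assay, at which 1 of the 3 values shown sits. Pyridin-2-yl in place of 4-methoxyphenyl gives an at least 1.3-fold higher number from compound 2 to compound 3 (0.11 log units; that floor lies within the scatter), and in place of 4-methylphenyl it gives an at least 1.4-fold higher number from compound 1 to compound 3 (0.15 log units; that floor lies within the scatter). Among these compounds, these are the first steps at this place to bring a hetero atom into the aromatic ring. Both are floors, and they leave a step beyond the scatter possible without showing one.

On these data alone, the true size of either step remains open. So does the reading for a pyridin-4-yl or a 4-aminophenyl group on this chain carbon.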